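Terminal phenyl in place of propyl on compound 2

A few compounds are considered here, and "the series" means these few. Any claim that something is new, unique, unknown or untested is made for them only; others in the source may bear on it.

Of the compounds shown here, two with a shared amide core have been measured. Compound 1 `CCCCCCCCCCC1(C(=O)Nc2cccc3c2OC(C)(C)C3)CCCC1` gives 500 nM in an assay for inhibition of acyl-CoA:cholesterol acyltransferase (Oryctolagus cuniculus), using microsomes (a higher number here means a weaker inhibitor, a lower number a stronger inhibitor), while compound 2 `CCCCCCCCC(C)(C)C(=O)Nc1c(C)cc(C)c2c1OC(C)(C)C2` gives 140 nM in this assay. Compound 2 thus stands at the lowest of the two numbers, and the gap to compound 1 lies beyond the usual scatter of repeated measurements, so compound 2 is the stronger inhibitor of the pair.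

Compound 3 `Cc1cc(C)c(NC(=O)C(C)(C)CCCCCc2ccccc2)c2c1CC(C)(C)O2` has not yet been measured. It differs from compound 2 in one place: phenyl in place of propyl on a saturated chain carbon, six bonds along the chain from a carbonyl carbon. Going by the values given here, no measured pair shows the effect of such a change here, so nothing in these data fixes its direction. For compound 3 a step that stays within the scatter, or at most a modest move in either direction, is expected, so that a 1.4-fold higher number from compound 2 to compound 3 (0.15 log units; within the scatter). Compound 3 is accordingly estimated at 200 nM in this assay, with a range from 70 nM to 600 nM.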

Compound 3, half-maximal inhibitory concentration: 120 nM
Beside the measured number, compound 3's estimate is 1.7-fold (0.22 log units) above it, and the stated range covers the measured number.
By their numbers in this assay, from the lowest: compounds 3 and 2 (each within the scatter of the next); then compound 1.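

Going by these compounds alone, the first single-place comparison here shows that, in this assay, phenyl can replace propyl, with a 1.2-fold lower number from compound 2 to compound 3 (0.07 log units; within the scatter). Compound 2 and compound 3 therefore lie within the scatter of each other, even though the entering group brings one six-membered aromatic ring of carbon only and more heavy atoms than the propyl it replaces. Nothing available offers an explanation for this result. Still open, going by these compounds, is whether the same holds for a pyridine ring at this place, or for a phenyl carrying a methoxy group or a carboxylic acid. Also open, on these data alone, are a shorter or longer chain bearing the phenyl and the same change made on compound 1.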